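Chloro to bromo on the vinyl compounds

The source may hold more compounds than are shown below. What is called first, only, known or untested is meant among the compounds shown, and "the series" means these compounds.

In a functional assay on L1210 cells (Mus musculus) for inhibition (on this read-out higher numbers stand for weaker inhibition and lower numbers for stronger inhibition), compound 1 `C/C=C/c1cc(=O)[nH]c(=O)n1C1O[C@H](CO)[C@@H](O)[C@H]1O` gives only a limit, > 35000 nM. Compound 2 `C=Cc1cc(O)nc(O)n1` reads 3000 nM in this assay. Compound 3 `C=Cc1nc(O)nc(O)c1Cl` reads 4500 nM in the same test, which places compound 3 level with compound 2, within the scatter of repeated measurements. Going by the values given here, compound 1 is joined to the other two by no measured step and adds nothing to the question here.

Compound 4 `C=Cc1nc(O)nc(O)c1Br` has not yet been measured. It keeps the core of compound 3 and carries a single change, bromo in place of chloro on an aromatic carbon, ortho to a vinyl group.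

Among the compounds with values here, one measured step bears on this change: a 1.5-fold higher number from compound 2 to compound 3 (0.18 log units; within the scatter). That step puts chloro in place of hydrogen on an aromatic carbon, and it stays within the scatter. Within the data shown here, no measured pair exchanges one halogen for another, so the support is indirect and the range is kept wide. Given a 1.5-fold higher number from compound 2 to compound 3 (0.18 log units; within the scatter), no step beyond the scatter is expected in this assay. The estimated step is a 1.1-fold lower number from compound 3 to compound 4 (0.05 log units; within the scatter). For compound 4 the estimate is 4000 nM, with an expected range from 1800 nM to 9000 nM.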

Compound 4, half-maximal inhibitory concentration: 11000 nM
The estimate for compound 4 lay 2.8-fold (0.44 log units) below the measured number; measured number above the stated range.
By their numbers in this assay, from the lowest: compounds 2 and 3 (each within the scatter of the next); then compound 4. At a limit, above all of these: compound 1.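

In this assay this aromatic carbon, ortho to the vinyl group, proves not to be indifferent to the choice of halogen: bromo in place of chloro gives a modest step beyond the scatter (a 2.4-fold higher number from compound 3 to compound 4 (0.39 log units; beyond the scatter)), whereas chloro in place of hydrogen had stayed within it (a 1.5-fold higher number from compound 2 to compound 3 (0.18 log units; within the scatter)). Bromo in place of hydrogen also clears the scatter (a 3.7-fold higher number from compound 2 to compound 4 (0.56 log units; beyond the scatter)), so among compounds 2, 3 and 4 only the bromo compound separates from the others, and it does so towards weaker inhibition. Nothing at hand bears on why the two halogens part here.

Open, on these data alone, is how iodo, a methyl group, an amine or a nitrile on this same carbon would read against the hydrogen of compound 2, and so whether the loss seen with bromo belongs to the heavier halogens alone or extends to other groups. Also open, as far as these compounds go, is whether the bromo step persists when the vinyl group gives way to an ethyl group or a longer chain.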